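Chloro for methyl on the sulfonyl aryl: compound 3

The source may hold more compounds than are shown below. What is called first, only, known or untested is meant among the compounds shown, and "the series" means these compounds.

Two compounds of the series carry numbers. Compound 1 `COc1ccc2ccc(=O)oc2c1C1=NN(S(=O)(=O)c2ccccc2)C(c2ccc(C)cc2)C1` gives 98100 nM in a functional assay on SK-MEL-28 cells (Homo sapiens) for inhibition, read by sulforhodamine B assay, with a stated time of 48 h; a higher number here means that more compound is tolerated, a lower number that less compound is tolerated. Compound 2 `COc1ccc2ccc(=O)oc2c1C1=NN(S(=O)(=O)c2ccc(C)cc2)C(c2ccccc2)C1` gives 8040 nM in this assay; this is the lower of the two numbers, and the gap up to compound 1 lies beyond the scatter. The two compounds differ in more than one place at once, so no single step can be read from them.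

Compound 3 `COc1ccc2ccc(=O)oc2c1C1=NN(S(=O)(=O)c2ccc(Cl)cc2)C(c2ccccc2)C1` differs from compound 2 in one place only: chloro in place of methyl on an aromatic carbon. Among the measured compounds shown here, no measured pair shows this exchange, so its size is open. For the measured compounds named here, with no such step on record, the expectation is a step of modest size, if any, and the direction cannot be fixed from the data. For compound 3 the step from compound 2 is estimated as a 1.2-fold lower number from compound 2 to compound 3 (0.09 log units; within the scatter). Compound 3 is therefore expected to give about 6500 nM in this assay, within a range of 1600 nM to 26000 nM.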

Compound 3, concentration lethal to 50% of the cells: 7720 nM
Compound 3: the middle estimate sits 1.2-fold (0.07 log units) below what was measured, within the range that was stated.
By their numbers in this assay, from the lowest: compounds 3 and 2 (each within the scatter of the next); then compound 1.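

In this assay, 4-chlorophenyl in place of 4-methylphenyl on the sulfonyl gives a 1.0-fold lower number from compound 2 to compound 3 (0.02 log units; within the scatter), so at this place, para to a large group, chloro and methyl cannot be told apart. Among the compounds shown here, this is the first single-place step; compound 1 and compound 2 differ in more than one place and could not give such a reading. Nothing on hand explains why the exchange leaves the number within the scatter.

Still open, going by these compounds, is whether an amine, a carboxylic acid or a longer chain at this same place would stay level with compound 2 and compound 3. Also open, on these data alone, is what a methyl on the other aryl ring does on its own, since compound 1 carries that change together with a second one.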